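Phenoxy for Phenyl on the Cyclohexyl-Bearing Core

The compounds below may be only part of what the source reports. "The series", "measured", "known", "first", "only" and "open" are said of these compounds alone.

Measured compounds:
compound 1, `Cc1[nH]c(=O)n(C)c1-c1ccc(-c2ccccc2)cc1`: 6300 nM
compound 2, `Cc1[nH]c(=O)n(C)c1-c1ccc(Oc2ccccc2)cc1`: 8100 nM
compound 3, `Cc1[nH]c(=O)n(C2CCCCC2)c1-c1ccc(-c2ccccc2)cc1`: 10900 nM

All three were tested in a functional assay on brain (Rattus norvegicus, strain Wistar) for inhibition; a higher number here means a weaker inhibitor, a lower number a stronger inhibitor. Compound 2 differs from compound 1 by phenoxy in place of phenyl on an aromatic carbon, a change that gave a 1.3-fold higher number from compound 1 to compound 2 (0.11 log units; within the scatter). Compound 3 differs from compound 1 in the core, namely (cyclohexyl in place of methyl on an aromatic nitrogen), and this gave a 1.7-fold higher number from compound 1 to compound 3 (0.24 log units; within the scatter).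

Compound 4, `Cc1[nH]c(=O)n(C2CCCCC2)c1-c1ccc(Oc2ccccc2)cc1`, has not yet been measured in this assay. It is made from compound 3 by phenoxy in place of phenyl on an aromatic carbon. This is the same kind of change as that from compound 1 to compound 2, though the surroundings of the place differ: in the earlier pair the place is para to a group of 8 heavy atoms, in the later pair para to a large group.

The step expected for compound 4 is a 1.3-fold higher number from compound 3 to compound 4 (0.11 log units; within the scatter), because the earlier step of a 1.3-fold higher number from compound 1 to compound 2 (0.11 log units; within the scatter) lay within the scatter and compound 3 stands at 10900 nM. Compound 4 is therefore estimated to give 14000 nM in this assay, with a range from 7000 nM to 28000 nM.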

Compound 4, half-maximal inhibitory concentration: 7900 nM
Estimate against measurement, compound 4: 1.8-fold (0.25 log units) above, within the range that was stated.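

In this assay, phenoxy in place of phenyl on the cyclohexyl-bearing core gave a 1.4-fold lower number from compound 3 to compound 4 (0.14 log units; within the scatter), and this step does not differ from the one on the methyl-bearing core: the same change on two cores in this assay, a 1.3-fold higher number (0.11 log units; within the scatter) from compound 1 to compound 2 and a 1.4-fold lower number (0.14 log units; within the scatter) from compound 3 to compound 4, 1.8-fold (0.25 log units) apart, within the scatter of two such steps. Cyclohexyl in place of methyl, with phenoxy already present, gave a 1.0-fold lower number from compound 2 to compound 4 (0.01 log units; within the scatter), and this step likewise does not differ from the one seen with phenyl present: the same change on two cores in this assay, a 1.7-fold higher number (0.24 log units; within the scatter) from compound 1 to compound 3 and a 1.0-fold lower number (0.01 log units; within the scatter) from compound 2 to compound 4, 1.8-fold (0.25 log units) apart, within the scatter of two such steps. The four compounds are thus compatible with either change carrying from one core to the other, but every step lies within the scatter, so they do not show that a change of measurable size would carry over, and the opposite directions of the paired steps do not establish a reversal.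

The compounds shown vary only between phenyl and phenoxy on the aromatic carbon and between methyl and cyclohexyl on the aromatic nitrogen. As far as these compounds go, it remains open whether an amine or a carboxylic acid at the first place, or a longer chain at the second, would give a step beyond the scatter, and whether such a step would carry between cores.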